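The source may hold more compounds than are shown below. What is called first, only, known or untested is meant among the compounds shown, and "the series" means these compounds.

Compound 1, `CNC(=O)c1cc(C(=O)N[C@H]2[C@@H]3COC[C@@H]32)c([C@@H](C)c2ccccc2)o1`: in an ADME assay on cells (Hepatocyte, Homo sapiens) for metabolic stability, read by LC-MS, with a stated time of 120 min (on this read-out lower numbers stand for slow clearance and higher numbers for fast clearance), compound 1 gives < 0.45 mL/min, which is a limit of the assay.
Compound 2, `CNC(=O)c1cc(C(=O)NC2CC2)cn(Cc2cccc3[nH]ccc23)c1=O`: in this assay compound 2 gives 2.9 mL/min.
Compound 3, `CNC(=O)c1cc(C(=O)N[C@H]2CC[C@H](O)CC2)c([C@@H](C)c2cccc(Cl)c2)o1`: in this assay compound 3 gives < 0.45 mL/min, again a limit of the assay rather than a number.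

Compound 3 therefore stands at the low end of what has been seen, at the limit of < 0.45 mL/min in this assay, at which 2 of the 3 values shown sit. Only compound 2 has a true number among the three. Among the measured compounds shown here, no step between two measured compounds that differ in one place is available. Compound 4, `CNC(=O)c1cc(C(=O)N[C@H]2CC[C@H](O)CC2)c([C@@H](C)c2ccccc2)o1`, differs from compound 3 by hydrogen in place of chloro on an aromatic carbon. The nearest point of comparison is compound 1, which also carries phenyl in this place and in this assay gives < 0.45 mL/min, a limit. On that basis the step that the limit leaves unreadable from compound 3 to compound 4 is expected to be none beyond the scatter, with compound 4 staying at the limit. Compound 4 is estimated at 0.35 mL/min, expected to fall between 0.15 mL/min and 0.9 mL/min.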

Compound 4, intrinsic clearance in a liver preparation (reported as CLH), per the amount of preparation that the assay uses: < 0.5 mL/min
Compound 4 was reported as a limit; the forecaster's own chance of this, stated with the estimate: 70%; the middle value does not contradict the limit.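

In this assay compound 1, compound 3 and compound 4 all sit at limits of the assay, and the steps from compound 3 and from compound 1 to compound 4 cannot be read. The compounds shown leave open whether hydrogen in place of chloro on an aromatic carbon moves clearance at all.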